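The source may report more compounds than this note shows. Statements on the series, on what has been measured and on what is new or still open speak of the compounds shown alone.

Measured in an ADME assay on microsomes from liver (Rattus norvegicus) for metabolic stability, read by LC-MS, using NADPH, with a stated time of 30 min, tested at 1 uM; a lower number here means slower removal, a higher number faster removal of the compound:
- Compound 1 `CC(C)c1noc(N2CCC(Oc3cc(N4CCc5cc(N6CCCCC6=O)ccc54)ncn3)CC2)n1`: 13 mL.min-1.g-1
- Compound 2 `CC(C)c1noc(N2CCC(Oc3cc(N4CCc5cc(N6CCCS6(=O)=O)ccc54)ncn3)CC2)n1`: 1 mL.min-1.g-1

Compound 2 stands lower of the two, at 1 mL.min-1.g-1. Compound 3 `CC(C)c1noc(N2CCC(Oc3cc(N4CCc5cc(N6CCCC6=O)ccc54)ncn3)CC2)n1` departs from it on an aromatic carbon, where 2-oxopyrrolidin-1-yl enters: a group of 6 heavy atoms (4 carbon, 1 nitrogen, 1 oxygen; one five-membered non-aromatic ring with 1 hetero atom) in place of a group of 7 heavy atoms (3 carbon, 1 nitrogen, 2 oxygen, 1 sulfur; one five-membered non-aromatic ring with 2 hetero atoms), on an aromatic carbon. No measurement covers this exact change. The nearest evidence is a 13-fold lower number from compound 1 to compound 2 (1.11 log units; beyond the scatter), a large step ending in the group that leaves here. Compound 3 regains a ring with one hetero atom, as in compound 1 at 13 mL.min-1.g-1, so a clear rise in this assay is expected, probably short of that value. The expected step is a 6.0-fold higher number from compound 2 to compound 3 (0.78 log units; beyond the scatter). For compound 3 the estimate is 6 mL.min-1.g-1, with an expected range of 2 mL.min-1.g-1 to 16 mL.min-1.g-1.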

Compound 3, intrinsic clearance in microsomes: 138 mL.min-1.g-1
For compound 3 the middle estimate is 23-fold (1.36 log units) below the measured one; the whole stated range lies below it.
By their numbers in this assay, from the lowest: compound 2; then compound 1; then compound 3.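

In this assay, this position on an aromatic carbon responds strongly even to ring size: 2-oxopyrrolidin-1-yl in place of 2-oxopiperidin-1-yl gives an 11-fold higher number from compound 1 to compound 3 (1.03 log units; beyond the scatter). A five-membered ring alone therefore does not keep the number low, since the two five-membered groups are separated by a 140-fold higher number from compound 2 to compound 3 (2.14 log units; beyond the scatter). No measured evidence bearing on this result is available. The compounds shown leave open how a six-membered ring carrying a sulfonyl group, or an open-chain acetamide, would behave at this position.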